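Compound 3 to compound 4: a new chain with nitrogen

The source may report more compounds than this note shows. Statements on the series, on what has been measured and on what is new or still open speak of the compounds shown alone.

Three alkyl variants on the shared core have been measured in a functional assay on LNCaP cells (Homo sapiens) for antiproliferative activity, read by WST assay, with a stated time of 3 days; on this read-out higher numbers stand for weaker inhibition and lower numbers for stronger inhibition. Compound 1 `CCCOc1c(-c2cc(OC)c(OC)c(OC)c2)oc2ccccc2c1=O` gives 5700 nM, compound 2 `CCCCCCOc1c(-c2cc(OC)c(OC)c(OC)c2)oc2ccccc2c1=O` gives 19600 nM, and compound 3 `CCC(C)Oc1c(-c2cc(OC)c(OC)c(OC)c2)oc2ccccc2c1=O` gives 9300 nM. Compound 3 stands level with compound 1, with the step of a 1.6-fold higher number from compound 1 to compound 3 (0.21 log units; within the scatter). Compound 2 is the weakest of the three, and the step to compound 3 reads a 2.1-fold lower number from compound 2 to compound 3 (0.32 log units; beyond the scatter).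

Next is compound 4 `CCN(CC)CCCCCOc1c(-c2cc(OC)c(OC)c(OC)c2)oc2ccccc2c1=O`, with 5-(diethylamino)pentyl in place of sec-butyl on an oxygen on an aromatic ring.

Going by the values given here, two measured steps bear on the chain part of this change. The step of a 3.4-fold higher number from compound 1 to compound 2 (0.54 log units; beyond the scatter) and the step of a 2.1-fold lower number from compound 2 to compound 3 (0.32 log units; beyond the scatter) both leave the hexyl compound with the highest number, so a long carbon chain alone would suggest a modest rise. Among the compounds with values here, neither step speaks to the nitrogen, as no measured compound carries one, and its contribution could offset that rise or reverse it. As far as these compounds go, no step beyond the scatter is therefore expected with any confidence, and the direction stays open, with a slight lean towards a lower number. The expected step is a 1.9-fold lower number from compound 3 to compound 4 (0.27 log units; within the scatter). For compound 4 the estimated value in this assay is 5000 nM, with an expected range of 1300 nM to 16000 nM.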

Compound 4, half-maximal inhibitory concentration: 10000 nM
Beside the measured number, compound 4's estimate is 2.0-fold (0.30 log units) below it; the measured number falls inside the stated range.
By their numbers in this assay, from the lowest: compounds 1, 3, 4 and 2 (each within the scatter of the next, the first and the last beyond it).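

In this assay the oxygen on an aromatic ring carries 5-(diethylamino)pentyl, with its 10 heavy atoms including 1 nitrogen, without any step beyond the scatter: the series reads a 1.1-fold higher number from compound 3 to compound 4 (0.03 log units; within the scatter) and also a 1.8-fold higher number from compound 1 to compound 4 (0.24 log units; within the scatter) and finally a 2.0-fold lower number from compound 2 to compound 4 (0.29 log units; within the scatter) so the new chain cannot be told apart from any of the three alkyl groups on this read-out. Going by these compounds alone, this is the first sign that this position accepts a chain ending in a nitrogen-bearing group, and the diethylamino in place of methyl comparison with the hexyl compound adds no change that can be read. Compound 4 also lies within the scatter of both compound 1 and compound 2, although those two differ beyond it, so it does not settle whether chain length or the nitrogen governs the number, and nothing available offers an explanation for the result.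

Still open, as far as these compounds go, is whether a shorter chain ending in diethylamino, such as 2-(diethylamino)ethyl, would give a step beyond the scatter. Also open, from the compounds shown here alone, is how a cyclic amine such as piperidine or morpholine, or a carboxylic acid, at the chain end would read at this position.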